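Furan-2-yl Ketone Variant of a Trimethoxyphenyl Series

The compounds below may be only part of what the source reports. "The series", "measured", "known", "first", "only" and "open" are said of these compounds alone.

Measured compounds:
compound 1 `COc1cc(-c2nnc3n2NC(c2ccco2)C(C(=O)c2ccccc2F)S3)cc(OC)c1OC` — > 100000 nM
compound 2 `COc1cc(-c2nnc3n2NC(c2ccco2)C(C(=O)c2ccc(Br)cc2)S3)cc(OC)c1OC` — 36400 nM
compound 3 `COc1ccc(C(=O)C2Sc3nnc(-c4cc(OC)c(OC)c(OC)c4)n3NC2c2ccco2)cc1` — > 100000 nM

In a functional assay on PC-3 cells (Homo sapiens) for cytotoxicity, read by MTT assay, with a stated time of 48 h (on this read-out higher numbers stand for weaker inhibition and lower numbers for stronger inhibition), compound 3 gives > 100000 nM, a limit of the assay rather than a number. Compound 2 gives 36400 nM. The step of an at least 2.7-fold higher number from compound 2 to compound 3 (0.43 log units; beyond the scatter) therefore leaves compound 3 among the weakest on the numbers shown. Compound 1 gives > 100000 nM, again a limit, so the step that the two limits leave unreadable from compound 1 to compound 3 cannot be read, while an at least 2.7-fold lower number from compound 1 to compound 2 (0.43 log units; beyond the scatter) is readable.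

Compound 4 `COc1cc(-c2nnc3n2NC(c2ccco2)C(C(=O)c2ccco2)S3)cc(OC)c1OC` differs from compound 3 by furan-2-yl in place of 4-methoxyphenyl on a carbonyl carbon. Among the compounds with values here, no measured step involves furan-2-yl at this carbonyl carbon; the three steps above only change the aryl group there, and two of the three values sit at the limit of > 100000 nM in this assay, at which 2 of the 3 values shown sit. With the aryl ketone at the limit and the step of an at least 2.7-fold higher number from compound 2 to compound 3 (0.43 log units; beyond the scatter) pointing to weaker inhibition, compound 4 is expected to remain weak. The estimate for compound 4 is 100000 nM, between 30000 nM and 300000 nM, which means an expected step of a number no higher from compound 3 to compound 4 (the limit leaves the size open).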

Compound 4, half-maximal inhibitory concentration: 58300 nM
Compound 4: the middle estimate sits 1.7-fold (0.23 log units) above what was measured, and the stated range covers the measured number.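

Furan-2-yl on the carbonyl carbon is the only group shown there that is not a substituted phenyl, and in this assay compound 4 gives a measured number, 58300 nM, rather than a limit. Against the two compounds held at a limit, the result reads as an at least 1.7-fold lower number from compound 3 to compound 4 (0.23 log units; that floor lies within the scatter) and an at least 1.7-fold lower number from compound 1 to compound 4 (0.23 log units; that floor lies within the scatter), so neither step shows a change beyond the scatter. Within the data shown here, the only comparison between two measured numbers, a 1.6-fold higher number from compound 2 to compound 4 (0.20 log units; within the scatter), shows that the five-membered furan-2-yl ring and 4-bromophenyl cannot be told apart at this position.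

How far compound 1 and compound 3 lie past the limit stays open: the limit of > 100000 nM in this assay, at which 2 of the 4 values shown sit.

Also open is how an amine or a carboxylic acid on this carbonyl carbon would read, as every group shown there is an aromatic ring.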